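A Pyrazole Replaces an Isothiazole on the Shared Core

The compounds below may be only part of what the source reports. "The series", "measured", "known", "first", "only" and "open" are said of these compounds alone.

Compound 3 `Cc1cc(-c2ccccc2OCC2=NCCN2)sn1` has been tested in a functional assay for activation of Alpha-1D adrenergic receptor (Homo sapiens), read by calcium flux; a lower number here means that less compound is needed, a higher number that more compound is needed for the effect. For compound 3 the result is a limit of the assay, < 100000 nM, and not a number. Two companions share its core. Compound 1 `c1ccc(-c2ccncc2)c(OCC2=NCCN2)c1` likewise gives only a limit in this assay, < 100000 nM. Compound 2 `c1csc(-c2ccccc2OCC2=NCCN2)c1` gives a real number in this assay, 15.9 nM. Two of the three values shown thus sit at the assay boundary (the limit of < 100000 nM in this assay, at which 2 of the 3 values shown sit), and every step among the three is unreadable in size: a step that the limit leaves unreadable from compound 1 to compound 2, a step that the two limits leave unreadable from compound 1 to compound 3 and a step that the limit leaves unreadable from compound 2 to compound 3. Compound 3 therefore stands at a limit, with a single measured number beside it.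

Compound 4 `Cn1nccc1-c1ccccc1OCC1=NCCN1` is the next compound to be measured. The change is 1-methyl-1H-pyrazol-5-yl in place of 3-methyl-1,2-thiazol-5-yl on an aromatic carbon. Among the compounds with values here, none of the measured steps carries a readable size, so no step can point in a direction for this change. Compound 2 shows that a five-membered aromatic ring on the shared core can give a low value, while compound 1 and compound 3 sit at the limit. Compound 4 is expected to land between these outcomes, which means an estimated step that the limit leaves unreadable from compound 3 to compound 4. The estimate for compound 4 in this assay is 5000 nM, with an expected range from 100 nM to 100000 nM.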

Compound 4, half-maximal effective concentration: < 100000 nM
Compound 4 gave a limit, no number (the forecaster's own chance of this, stated with the estimate: 40%); the middle value lies beyond the limit too.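

In this assay compound 4 gives < 100000 nM, which is a limit of the assay and not a number. Its steps to compound 1, compound 2 and compound 3 therefore cannot be read in size, because the values gather at one boundary: the limit of < 100000 nM in this assay, at which 3 of the 4 values shown sit.

The compounds shown leave open how the true values of compound 1, compound 3 and compound 4 compare with that of compound 2.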